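Replacing the 4-iodophenyl group in the series

The compounds below may be only part of what the source reports. "The series", "measured", "known", "first", "only" and "open" are said of these compounds alone.

In an ADME assay on MDBK cells (Bos taurus) for cytotoxicity, read by MTT assay, with a stated time of 96 h (a higher number here means that more compound is tolerated, a lower number that less compound is tolerated), compound 1 `CC[C@H]1CC[C@H](c2ccc(NC(=S)Nc3cccc(C(F)(F)F)c3)cc2)CC1` gives 9000 nM and compound 3 `Fc1ccc(NC(=S)Nc2cccc(C(F)(F)F)c2)cc1Cl` gives 11000 nM while compound 2 `FC(F)(F)c1cccc(NC(=S)Nc2ccc(I)cc2)c1` gives 9500 nM and so stands within the scatter of both. Compound 4 `C=C(C)CNC(=S)Nc1cccc(C(F)(F)F)c1` carries 2-methylprop-2-en-1-yl in place of 4-iodophenyl on an amide-type nitrogen with no ring in the entering group. Within the data shown here, the only measured step is a 1.1-fold higher number from compound 1 to compound 2 (0.02 log units; within the scatter) for iodo in place of 4-ethylcyclohexyl on an aromatic carbon. Among the measured compounds shown here, it lies within the scatter but concerns another place, so no measured step covers this change. A moderate rise in this assay is tentatively expected, with compound 2 at 9500 nM as the starting point. The expected step is a 2.3-fold higher number from compound 2 to compound 4 (0.36 log units; beyond the scatter) on this estimate. Compound 4 is estimated at 22000 nM (expected range 8000 nM to 60000 nM).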

Compound 4, half-maximal cytotoxic concentration: > 100000 nM
Compound 4 ended at the assay's limit; the forecaster's own chance of this, stated with the estimate: 15%; middle value at least 4.5-fold (0.65 log units) away from the limit.
By their numbers in this assay, from the lowest: compounds 1, 2 and 3 (each within the scatter of the next). At a limit, above all of these: compound 4.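

Swapping substituents on the aromatic ring left the numbers in this assay within the scatter, as in a 1.1-fold higher number from compound 1 to compound 2 (0.02 log units; within the scatter), but this nitrogen responds strongly once the ring itself goes. 2-methylprop-2-en-1-yl in place of 4-iodophenyl gives an at least 10-fold higher number from compound 2 to compound 4 (1.02 log units; beyond the scatter), the only step beyond the scatter so far. Compound 4 is a limit and not a number: the limit of > 100000 nM in this assay, at which 1 of the 4 values shown sits.

The compounds shown do not separate the loss of the ring from the entry of the double bond. A saturated 2-methylpropyl chain or a benzyl group on the same nitrogen would address that.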